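The source may report more compounds than this note shows. Statements on the series, on what has been measured and on what is new or still open speak of the compounds shown alone.

Measured compounds:
- compound 1 `COc1ccccc1-c1cccc(S(=O)(=O)N2CCC(N3CCC(C)CC3)CC2)c1`: 21 nM
- compound 2 `CC1CCN(C2CCN(S(=O)(=O)c3cccc4cnccc34)CC2)CC1`: 225 nM

In a functional assay on DLD-1 cells (Homo sapiens) for antiproliferative activity, read by CellTiter-Glo, with a stated time of 72 h (on this read-out higher numbers stand for weaker inhibition and lower numbers for stronger inhibition), compound 1 gives 21 nM, the lowest of the two numbers. Compound 2 gives 225 nM in this assay, a higher number that lies beyond the usual scatter. Compound 3 `CC1CCN(C2CCN(S(=O)(=O)c3cccc(-c4ccc5ccccc5c4)c3)CC2)CC1` differs from compound 1 in one place: naphthalen-2-yl in place of 2-methoxyphenyl on an aromatic carbon. For the measured compounds named here, no pair of measured compounds shows this change, so the expectation rests on compound 1 alone. Compound 3 is expected to give about 40 nM in this assay, within 10 nM to 160 nM. The step of a 1.9-fold higher number from compound 1 to compound 3 (0.28 log units; within the scatter) is expected to be small, most likely within the scatter, with a slight lean toward a higher number.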

Compound 3, half-maximal inhibitory concentration: 2 nM
Estimate against measurement, compound 3: 20-fold (1.30 log units) above, and the stated range ends above it.
By their numbers in this assay, from the lowest: compound 3; then compound 1; then compound 2.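

In this assay, naphthalen-2-yl in place of 2-methoxyphenyl on this aromatic carbon brings an 11-fold lower number from compound 1 to compound 3 (1.02 log units; beyond the scatter), so the group at this place still moves the number strongly. The group that enters carries 2 six-membered aromatic rings of carbon only and no hydrogen-bond acceptor, and no measurement here gives a reason for the step. The compounds shown leave open how a plain phenyl or a naphthalen-1-yl would read at this place, and so whether the second ring or the absence of the methoxy oxygen goes with the step.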